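Replacing 2,3,4-trimethoxyphenyl with 3-bromo-4-hydroxyphenyl in compound 4

The source may report more compounds than this note shows. Statements on the series, on what has been measured and on what is new or still open speak of the compounds shown alone.

Compound 1 `COc1cc2ncnc(Nc3ccc(F)c(Cl)c3)c2cc1NC(=O)N/N=C/c1cccc(Br)c1`, compound 2 `COc1cc2ncnc(Nc3ccc(F)c(Cl)c3)c2cc1NC(=O)N/N=C/c1ccc(C#N)cc1` and compound 3 `COc1cc2ncnc(Nc3ccc(F)c(Cl)c3)c2cc1NC(=O)N/N=C/c1ccc(OC)c(OC)c1OC` share one core and differ in a single aromatic group. Among the compounds with values here, in a functional assay on MCF7 cells (Homo sapiens) for cytotoxicity, read by MTT assay, with a stated time of 72 h (a lower number here means a stronger inhibitor, a higher number a weaker inhibitor), compound 1 gives 27100 nM, the only actual number so far. The result for compound 2 is "not determined" (no result reported). Compound 3 is recorded as "not active" (no number reported), so it has no number that could place it on a scale.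

Compound 4 `COc1cc2ncnc(Nc3ccc(F)c(Cl)c3)c2cc1NC(=O)N/N=C/c1ccc(O)c(Br)c1` has not yet been measured. The structural change 3-bromo-4-hydroxyphenyl in place of 2,3,4-trimethoxyphenyl on a carbon with a double bond to nitrogen puts 3-bromo-4-hydroxyphenyl in place of 2,3,4-trimethoxyphenyl on a carbon with a double bond to nitrogen. Within the data shown here, no measured pair shows the size of such a swap in this assay. A modest step is expected, towards stronger inhibition than compound 3 but still weak, since compound 1, which also carries a bromine, gives only 27100 nM. The estimated value for compound 4 is 20000 nM, with an expected range from 6000 nM to 60000 nM.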

Compound 4, half-maximal inhibitory concentration: "not active" (no number reported)
Compound 4 has no reported number here, so the estimate cannot be set against anything.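

Compound 3 and compound 4 are both recorded as not active in this assay, without a number, so no step can be read between them. No measured evidence bears on this result. The compounds shown leave open how large the effect of swapping these two aromatic groups is.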